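The source may report more compounds than this note shows. Statements on the series, on what has been measured and on what is new or still open speak of the compounds shown alone.

Compound 1 `COc1ccc(-n2c(SC)nnc2-c2cc(OC)c(OC)c(OC)c2)cc1` is the parent of the set, carrying the methylsulfanyl group on its core. In a functional assay on HCT-116 cells (Homo sapiens) for inhibition, read by MTT assay, with a stated time of 48 h (a lower number here means a stronger inhibitor, a higher number a weaker inhibitor), compound 1 gives only a limit, > 60000 nM, with no number behind it. Within the data shown here, the only evidence on the measured steps is that limit, (the limit of > 60000 nM in this assay, at which 1 of the 3 values shown sits), so the position of compound 1 on the scale is open downward only by what the sulfanyl variants show.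

Compound 2 `COc1ccc(-n2c(SCc3ccccc3)nnc2-c2cc(OC)c(OC)c(OC)c2)cc1` has phenyl in place of hydrogen on a saturated chain carbon bound to a sulfur, and in this assay compound 2 gives 42400 nM. Compound 3 `COc1ccc(-n2c(SCc3ccc(F)cc3)nnc2-c2cc(OC)c(OC)c(OC)c2)cc1` carries 4-fluorophenyl at the same place, and in this assay compound 3 gives 38700 nM. The two steps from the parent are an at least 1.4-fold lower number from compound 1 to compound 2 (0.15 log units; that floor lies within the scatter) and an at least 1.5-fold lower number from compound 1 to compound 3 (0.19 log units; that floor lies within the scatter); between the two aryl variants the step is a 1.1-fold lower number from compound 2 to compound 3 (0.04 log units; within the scatter).

Compound 4 `COc1ccc(-n2c(SCC(=O)c3ccccc3)nnc2-c2cc(OC)c(OC)c(OC)c2)cc1` is the next member, differing from compound 1 by benzoyl in place of hydrogen on a saturated chain carbon bound to a sulfur. Among the measured compounds shown here, the steps that bear on it are those from compound 1 to compounds 2 and 3, both only floors and both within the scatter, so for compound 4 no more than a small movement in the same direction is expected, an at least 1.7-fold lower number from compound 1 to compound 4 (0.23 log units; that floor lies within the scatter). The value estimated for compound 4 is 35000 nM, within 12000 nM to 100000 nM.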

Compound 4, half-maximal inhibitory concentration: > 60000 nM
Compound 4: no number, only a limit; the forecaster's own chance of this, stated with the estimate: 25%; middle value at least 1.7-fold (0.23 log units) from the limit.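

With benzoyl in place of phenyl or 4-fluorophenyl on a saturated chain carbon bound to a sulfur, this assay gives an at least 1.4-fold higher number from compound 2 to compound 4 (0.15 log units; that floor lies within the scatter) and an at least 1.5-fold higher number from compound 3 to compound 4 (0.19 log units; that floor lies within the scatter), so the earlier movement away from the limit is not carried over to this group, though neither floor establishes a real separation from the aryl variants. Compound 4 gives only a limit, so a six-membered aromatic ring entering at this place does not by itself yield a measurable number; in the benzoyl form the compound returns to the limit shared with the parent: the limit of > 60000 nM in this assay, at which 2 of the 4 values shown sit.

The step from compound 1 to compound 4 cannot be read, as both ends are limits, and nothing shows whether benzoyl differs from hydrogen at this place.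

On these data alone, the steps from the two aryl variants stand only as floors, and their real size remains open. Also open, as far as these compounds go, is how an amine or a carboxylic acid in place of hydrogen on the same saturated chain carbon would read in this assay, and whether any group there gives a step beyond the scatter.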